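Sugar stereocentre inversion from compound 2 to compound 4

This account rests on a few compounds, and the source may have more. Where it says the series, first, only, none or still open, it means among the compounds named here.

Compound 2 `CCCNc1nc2cc(Cl)c(Cl)cc2n1[C@@H]1O[C@@H](CO)[C@@H](O)[C@H]1O` sits at a limit in a functional assay on KB cells (Homo sapiens) for inhibition (a higher number here means a weaker inhibitor, a lower number a stronger inhibitor), where compound 2 gives > 100000 nM. Compound 3 `CSc1nc2cc(Cl)c(Cl)cc2n1[C@@H]1O[C@@H](CO)[C@@H](O)[C@H]1O` likewise sits at a limit and gives > 100000 nM in this assay. Among the measured compounds shown here, compound 1 `OC[C@@H]1O[C@@H](n2c(SCc3ccccc3)nc3cc(Cl)c(Cl)cc32)[C@H](O)[C@@H]1O` carries the only read number, 40000 nM in this assay. The steps of an at least 2.5-fold higher number from compound 1 to compound 2 (0.39 log units; beyond the scatter) and an at least 2.5-fold higher number from compound 1 to compound 3 (0.39 log units; beyond the scatter) both run up to the limit (the limit of > 100000 nM in this assay, at which 2 of the 3 values shown sit), and a step that the two limits leave unreadable from compound 2 to compound 3 cannot be read. Compound 4 `CCCNc1nc2cc(Cl)c(Cl)cc2n1[C@@H]1O[C@H](CO)[C@@H](O)[C@H]1O` keeps every atom of compound 2; the difference is the two compounds have the same atoms and bonds and differ only in configuration as drawn: 1 of 4 stereo elements differ; a stereocentre at a saturated ring carbon is drawn S in compound 2 and R in compound 4. For the measured compounds named here, no measured step touches a stereocentre, so no direction beyond the scatter is expected, and the step that the limit leaves unreadable from compound 2 to compound 4 is expected to stay within it. Compound 4 is expected at 120000 nM, between 40000 nM and 400000 nM, most probably reported again only as a limit.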

Compound 4, half-maximal inhibitory concentration: > 100000 nM
Compound 4: no number, only a limit; the forecaster's own chance of this, stated with the estimate: 70%; the middle value does not contradict the limit.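

Compound 2 and compound 4 both stand only at a limit in this assay, and the step between them cannot be read. On these data alone, whether the configuration at this saturated ring carbon alters inhibition stays open.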